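Aryl against acyl on the ring nitrogen: tolerability notes

This account rests on a few compounds, and the source may have more. Where it says the series, first, only, none or still open, it means among the compounds named here.

Compound 3 `CC(C)C(=O)N1CCN(c2cc(NCCN)c3ccccc3n2)CC1` is read in an ADME assay on HEp-2 cells (Homo sapiens) for cytotoxicity, read by CCK-8 assay, with a stated time of 6 days (a higher number here means that more compound is tolerated, a lower number that less compound is tolerated), only as a limit, > 100000 nM. Compound 2 `CCC(=O)N1CCN(c2cc(NCCN)c3ccccc3n2)CC1` likewise gives only a limit, > 100000 nM. Compound 1 `NCCNc1cc(N2CCN(c3ccccc3Cl)CC2)nc2ccccc12` gives 20800 nM. Both acyl replacements of the 2-chlorophenyl group raise the tolerated concentration: an at least 4.8-fold higher number from compound 1 to compound 2 (0.68 log units; beyond the scatter) and an at least 4.8-fold higher number from compound 1 to compound 3 (0.68 log units; beyond the scatter). The step that the two limits leave unreadable from compound 2 to compound 3 cannot be sized because the limit of > 100000 nM in this assay, at which 2 of the 3 values shown sit, covers both ends of it. Compound 4 `NCCNc1cc(N2CCN(c3ccc(Cl)cc3)CC2)nc2ccccc12` differs from compound 3 by 4-chlorophenyl in place of isopropylcarbonyl on an amine nitrogen in a ring. This roughly reverses the change from compound 1 to compound 3, with 4-chlorophenyl rather than 2-chlorophenyl entering, so a fall is expected, an at least 4.0-fold lower number from compound 3 to compound 4 (0.60 log units; beyond the scatter), back toward the number of compound 1. Compound 4 is estimated at 25000 nM, between 8000 nM and 100000 nM.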

Compound 4, half-maximal cytotoxic concentration: 6600 nM
For compound 4 the middle estimate is 3.8-fold (0.58 log units) above the measured one; measured number outside the range, below it.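

In this assay the amine nitrogen in the ring responds not only to aryl against acyl but also to the choice of aryl group, since 4-chlorophenyl in place of 2-chlorophenyl gives a 3.2-fold lower number from compound 1 to compound 4 (0.50 log units; beyond the scatter). Against the acyl groups, 4-chlorophenyl gives an at least 15-fold lower number from compound 3 to compound 4 (1.18 log units; beyond the scatter) and an at least 15-fold lower number from compound 2 to compound 4 (1.18 log units; beyond the scatter). Compound 2 and compound 3 stand only as limits, so both sizes are minimums: the limit of > 100000 nM in this assay, at which 2 of the 4 values shown sit.

On these data alone, it remains open where an unsubstituted phenyl group falls at this nitrogen. As far as these compounds go, it is also open whether a benzoyl group, with its carbonyl and aromatic ring, tracks the acyl or the aryl compounds.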